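Moving the methoxy group on compound 3

This account rests on a few compounds, and the source may have more. Where it says the series, first, only, none or still open, it means among the compounds named here.

Values in a functional assay on A16-F10 cells (Homo sapiens) for antiproliferative activity, read by MTT assay, with a stated time of 48 h (a lower number here means a stronger inhibitor, a higher number a weaker inhibitor), stand as follows:
Compound 1 `COc1ccccc1CNc1ccc2ncnc(Nc3cccc(Br)c3)c2c1` gives 12500 nM
Compound 2 `Brc1cccc(Nc2ncnc3ccc(NCc4ccccc4Br)cc23)c1` gives 4380 nM
Compound 3 `COc1ccccc1CNc1ccc2ncnc(Nc3cccc(Cl)c3)c2c1` gives 14800 nM

Compound 3 at 14800 nM stands level with compound 1 within the scatter, while compound 2 shows a lower number at 4380 nM in the same test. Compound 4 `COc1ccc(CNc2ccc3ncnc(Nc4cccc(Cl)c4)c3c2)cc1` has not been measured. Its difference from compound 3 is 4-methoxyphenyl in place of 2-methoxyphenyl on a saturated chain carbon bound to a nitrogen on an aromatic ring and amounts to 4-methoxyphenyl in place of 2-methoxyphenyl on a saturated chain carbon bound to a nitrogen on an aromatic ring. Going by the values given here, two measured steps bear on this only indirectly. Bromo in place of methoxy gave a 2.9-fold lower number from compound 1 to compound 2 (0.46 log units; beyond the scatter) and chloro in place of bromo gave a 1.2-fold higher number from compound 1 to compound 3 (0.07 log units; within the scatter) in the series. Among the compounds with values here, no measured step moves the methoxy group, so no change beyond the scatter is expected in this assay and neither direction is favoured. The expected change is a 1.1-fold lower number from compound 3 to compound 4 (0.06 log units; within the scatter) as a working estimate. For compound 4 the estimated value is 13000 nM with an expected range from 5500 nM to 30000 nM in this test.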

Compound 4, half-maximal inhibitory concentration: 8430 nM
Beside the measured number, compound 4's estimate is 1.5-fold (0.19 log units) above it, within the range that was stated.
By their numbers in this assay, from the lowest: compounds 2, 4, 1 and 3 (each within the scatter of the next, the first and the last beyond it).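

In this assay, going by these compounds alone, the change of 2-methoxybenzyl to 4-methoxybenzyl gives a 1.8-fold lower number from compound 3 to compound 4 (0.24 log units; within the scatter), the first direct reading at this position, and it does not separate the two compounds. Moving the methoxy group therefore stays inside the scatter, as does chloro in place of bromo, whereas only bromo in place of methoxy, a 2.9-fold lower number from compound 1 to compound 2 (0.46 log units; beyond the scatter), goes beyond it. No measurement given here accounts for this result.

Still open, from the compounds shown here alone, is whether 4-methoxyphenyl reads the same with bromo in place of chloro. Also open, going by these compounds, is whether an amine or a carboxylic acid in place of the methoxy group would change the number beyond the scatter.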